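Sulfonyl aryl replacement on the piperidinyl ketone core

The source may report more compounds than this note shows. Statements on the series, on what has been measured and on what is new or still open speak of the compounds shown alone.

Measured in an assay on brain for displacement of a labelled ligand from 5-hydroxytryptamine receptor 4 (Cavia porcellus), with a stated time of 30 min, in the presence of a further agent that is not named here; a lower number here means a stronger inhibitor, a higher number a weaker inhibitor:
compound 1 `COc1ccc(S(=O)(=O)NCCN2CCC(CCC(=O)c3cc(Cl)c(N)cc3OC)CC2)cc1Cl`: 22.5 nM
compound 2 `COc1cc(N)c(Cl)cc1C(=O)CCC1CCN(CCNS(=O)(=O)c2ccc3c(c2)NC(=O)CO3)CC1`: 6.2 nM
compound 3 `COc1ccc(S(=O)(=O)NCCN2CCC(CCC(=O)c3cc(Cl)c(N)cc3OC)CC2)cc1Br`: 24.3 nM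

Compound 1 has the second highest number of the three; compound 3 sits within the scatter of it, a 1.1-fold higher number from compound 1 to compound 3 (0.03 log units; within the scatter), while compound 2 lies clearly lower, a 3.6-fold lower number from compound 1 to compound 2 (0.56 log units; beyond the scatter). Compound 4 `COc1cc(N)c(Cl)cc1C(=O)CCC1CCN(CCNS(=O)(=O)c2ccc(N)cc2)CC1` differs from compound 1 in one place: 4-aminophenyl in place of 3-chloro-4-methoxyphenyl on a sulfonyl sulfur. The step from compound 1 to compound 2 is the one that bears on it, since there too the same aryl on the sulfonyl sulfur was exchanged, with a modest gain; the halogen swap from compound 1 to compound 3 showed that small changes on that ring stay within the scatter. Compound 4 is expected to show a small step toward a lower number, a 1.5-fold lower number from compound 1 to compound 4 (0.18 log units; within the scatter), or none beyond the scatter. The estimate for compound 4 is 15 nM, within 6 nM to 40 nM.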

Compound 4, inhibition constant: 1.97 nM
Compound 4: middle estimate off by 7.6-fold (0.88 log units), on the high side; measured number outside the range, below it.
By their numbers in this assay, from the lowest: compound 4; then compound 2; then compounds 1 and 3 (each within the scatter of the next).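

In this assay, the sulfonyl sulfur takes 4-aminophenyl far better than the halogenated aryls, with an 11-fold lower number from compound 1 to compound 4 (1.06 log units; beyond the scatter) and a 12-fold lower number from compound 3 to compound 4 (1.09 log units; beyond the scatter), while the halogen swap alone had moved nothing beyond the scatter. The gain does not depend on the larger group of compound 2, as a 3.1-fold lower number from compound 2 to compound 4 (0.50 log units; beyond the scatter) shows. Nothing available accounts for these steps.

Compound 4 adds the amine and loses the chloro and methoxy groups in one step, so their shares remain unresolved. Unsubstituted phenyl and 4-hydroxyphenyl on the sulfonyl sulfur would help separate them.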